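Phenoxy for tert-Butylphenyl, Tried on a Second Core

The source may hold more compounds than are shown below. What is called first, only, known or untested is meant among the compounds shown, and "the series" means these compounds.

Measured so far:
compound 1 `COc1cccc(CNCCCNc2ccnc3cc(Oc4ccccc4)ccc23)c1O`: 6800 nM
compound 2 `COc1cccc(CNCCCNc2ccnc3cc(-c4ccc(C(C)(C)C)cc4)ccc23)c1O`: 690 nM
compound 3 `CC(C)(C)c1ccc(-c2ccc3c(NCCCNCc4ccco4)ccnc3c2)cc1`: 3150 nM

Of the compounds shown here, three have been tested in an ADME assay on HepG2 cells (Homo sapiens) for cytotoxicity, read by luminescence, CellTiter-Glo and ATP content, with a stated time of 72 h; on this read-out lower numbers stand for an effect already at smaller amounts and higher numbers for an effect only at larger amounts of compound. Compound 2 gives the lowest number of the three, compound 1 the highest, and compound 3 stands between them, with each of these gaps beyond the scatter of repeated measurements.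

Compound 1 is obtained from compound 2 by a single change, (phenoxy in place of 4-(tert-butyl)phenyl on an aromatic carbon). This change gave a 9.9-fold higher number from compound 2 to compound 1 (0.99 log units; beyond the scatter), so the phenoxy compound needs more material than the tert-butylphenyl compound before cells are affected.

Compound 4 `c1ccc(Oc2ccc3c(NCCCNCc4ccco4)ccnc3c2)cc1` is not yet measured. It stands to compound 3 as compound 1 stands to compound 2: the difference is phenoxy in place of 4-(tert-butyl)phenyl on an aromatic carbon, and the place of the change is described in the same words in both cases, so it is the same change on a different core. The two cores differ in the group on the chain, (furan-2-yl in place of 2-hydroxy-3-methoxyphenyl on a saturated chain carbon bound to an amine nitrogen), and that difference gave a 4.6-fold higher number from compound 2 to compound 3 (0.66 log units; beyond the scatter).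

For the measured compounds named here, from compound 3 to compound 4 a step of a 7.9-fold higher number from compound 3 to compound 4 (0.90 log units; beyond the scatter) is expected, because the same change gave a 9.9-fold higher number from compound 2 to compound 1 (0.99 log units; beyond the scatter), and only one earlier example of it exists. For compound 4 the estimated value in this assay is 25000 nM, expected to lie between 10000 nM and 60000 nM.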

Compound 4, half-maximal effective concentration in the HepG2 assay: 15200 nM
The estimate for compound 4 lay 1.6-fold (0.22 log units) above the measured number, and the stated range covers the measured number.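

In the HepG2 assay compound 4 gives 15200 nM, and phenoxy in place of 4-(tert-butyl)phenyl gave a 4.8-fold higher number from compound 3 to compound 4 (0.68 log units; beyond the scatter) on the core that carries furan-2-yl. Cells were again affected only at larger amounts, and the step on this core matches the earlier one as closely as such measurements can tell: the same change on two cores in the HepG2 assay, a 9.9-fold higher number (0.99 log units; beyond the scatter) from compound 2 to compound 1 and a 4.8-fold higher number (0.68 log units; beyond the scatter) from compound 3 to compound 4, 2.0-fold (0.31 log units) apart, within the scatter of two such steps. The change in the chain group can be read in the same way, since furan-2-yl in place of 2-hydroxy-3-methoxyphenyl gave a 2.2-fold higher number from compound 1 to compound 4 (0.35 log units; beyond the scatter) on the phenoxy compounds, which also matches its earlier step: the same change on two cores in the HepG2 assay, a 4.6-fold higher number (0.66 log units; beyond the scatter) from compound 2 to compound 3 and a 2.2-fold higher number (0.35 log units; beyond the scatter) from compound 1 to compound 4, 2.0-fold (0.31 log units) apart, within the scatter of two such steps. So on these four compounds each change kept its direction and roughly its size when carried to the other core, but two pairs show neither why this happens nor that it would hold on further cores. In a physicochemical assay for solubility, with a stated time of 18 h, at pH 7.4 (on this read-out higher numbers stand for higher solubility and lower numbers for lower solubility), compound 3 gives 32000 nM and compound 4 gives 14500 nM. In the physicochemical assay the step of a 2.2-fold lower number from compound 3 to compound 4 (0.34 log units; beyond the scatter) is shown on one core alone, leaving its transfer unknown.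

A plain phenyl group on the same aromatic carbon would help separate the loss of the tert-butyl group from the entry of the oxygen, and the compounds shown leave that split open. They also leave open whether the phenoxy step would keep its size with a longer chain or with a carboxylic acid on the chain group.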